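The source may report more compounds than this note shows. Statements on the series, on what has been measured and on what is new or still open speak of the compounds shown alone.

Measured compounds:
- compound 1 `NCCNc1cc(N2CCc3ccccc3C2)nc2ccccc12`; in an ADME assay on HEp-2 cells (Homo sapiens) for cytotoxicity, read by CCK-8 assay, with a stated time of 5 days (a higher number here means that more compound is tolerated, a lower number that less compound is tolerated), compound 1 gives 15000 nM
- compound 2 `NCCNc1cc(N2CCCc3ccccc3C2)nc2ccc(C(F)(F)F)cc12`; in this assay compound 2 gives 6700 nM
- compound 3 `Cc1ccc2nc(N3CCCc4ccc(F)cc4C3)cc(NC(C)CN)c2c1`; in this assay compound 3 gives 25000 nM

Compound 3 gives the highest of the three numbers in this assay. Its nearest neighbour is compound 1, whose number lies within the scatter of compound 3, so the two cannot be ordered. Compound 2 stands furthest away, with a number below that of compound 3 by a margin beyond the scatter. Within the data shown here, no two of the three measured compounds differ in only one place, so no single step between measured compounds can be read off.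

Compound 4 `CC(=O)NCCNc1cc(N2CCCc3ccc(F)cc3C2)nc2ccc(C)cc12` is the next compound to be run in this assay. It differs from compound 3 as follows: 2-acetamidoethyl in place of 1-(aminomethyl)ethyl on a nitrogen on an aromatic ring.

No measured pair carries this change, so nothing shown in this assay fixes its direction. Both the leaving and the entering group are open chains with one hydrogen-bond donor and one hydrogen-bond acceptor and no net charge, and the rest of the structure is unchanged. The expectation is therefore a step of no size beyond the scatter, if anything slightly upward, so that the step from compound 3 to compound 4 in this assay is estimated as a 1.2-fold higher number from compound 3 to compound 4 (0.08 log units; within the scatter). Compound 4 is expected to give about 30000 nM in this assay, with a range from 12000 nM to 75000 nM.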

Compound 4, half-maximal cytotoxic concentration: 66000 nM
Estimate against measurement, compound 4: 2.2-fold (0.34 log units) below; the range from low to high includes it.
By their numbers in this assay, from the lowest: compound 2; then compounds 1 and 3 (each within the scatter of the next); then compound 4.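

In this assay, among these compounds, the chain on a nitrogen on an aromatic ring proves to be a place that can move the number: 2-acetamidoethyl in place of 1-(aminomethyl)ethyl gives a 2.6-fold higher number from compound 3 to compound 4 (0.42 log units; beyond the scatter), the first single-place step that can be read. The two chains have the same counts of hydrogen-bond donors and acceptors and neither carries a net charge, so these shared counts do not by themselves fix the number; the entering chain differs in its heavy atoms, including its oxygen, and in its double bond outside aromatic rings. No measurement at hand bears on what lies behind the step.

Going by these compounds, it remains open which part of the change carries the step, and a 3-acetamidopropyl chain or a chain ending in a carboxylic acid at this nitrogen would test how far it depends on the end of the chain and on its length. On these data alone, whether a step of this size also appears on the cores of compound 1 and compound 2 remains open as well.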